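A few compounds are considered here, and "the series" means these few. Any claim that something is new, unique, unknown or untested is made for them only; others in the source may bear on it.

Measured in a functional assay on HCT-116 cells (Homo sapiens) for antiproliferative activity, read by MTT assay; a higher number here means a weaker inhibitor, a lower number a stronger inhibitor:
- compound 1 `Cn1c(=O)c(=O)n(C2CCCC2)c2nc(N/N=C/c3ccc(C(F)(F)F)cc3)ncc21`: 29000 nM
- compound 2 `Cc1ccc(/C=N/Nc2ncc3c(n2)n(C2CCCC2)c(=O)c(=O)n3C)cc1C`: 62900 nM
- compound 3 `COc1ccc(/C=N/Nc2ncc3c(n2)n(C2CCCC2)c(=O)c(=O)n3C)c(OC)c1`: > 100000 nM (a limit)

Compound 3 has no exact number in this assay, only the limit > 100000 nM.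

Compound 4 `Cn1c(=O)c(=O)n(C2CCCC2)c2nc(N/N=C/c3ccc(O)c(Br)c3)ncc21` carries 3-bromo-4-hydroxyphenyl in place of 2,4-dimethoxyphenyl on a carbon with a double bond to nitrogen.

Two measured steps introduce the group that leaves here: an at least 3.4-fold higher number from compound 1 to compound 3 (0.53 log units; beyond the scatter) and an at least 1.5-fold higher number from compound 2 to compound 3 (0.20 log units; that floor lies within the scatter). Only the first clearly exceeds the scatter. Leaving 2,4-dimethoxyphenyl is therefore expected to lower the number modestly, though the new group is untested.

The expected step is an at least 2.8-fold lower number from compound 3 to compound 4 (0.45 log units; beyond the scatter).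

For compound 4 the estimate is 35000 nM, with an expected range of 10000 nM to 100000 nM.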

Compound 4, half-maximal inhibitory concentration: 17700 nM
Beside the measured number, compound 4's estimate is 2.0-fold (0.30 log units) above it; the range from low to high includes it.
By their numbers in this assay, from the lowest: compounds 4 and 1 (each within the scatter of the next); then compound 2. At a limit, above all of these: compound 3.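

In this assay, 3-bromo-4-hydroxyphenyl is the only group shown at this place with a hydrogen-bond donor, and it gives an at least 5.6-fold lower number from compound 3 to compound 4 (0.75 log units; beyond the scatter) and a 3.6-fold lower number from compound 2 to compound 4 (0.55 log units; beyond the scatter). Against 4-(trifluoromethyl)phenyl it gives a 1.6-fold lower number from compound 1 to compound 4 (0.21 log units; within the scatter), so these two groups cannot be told apart here. The step from compound 3 is only a floor, as compound 3 has a limit rather than a number: the limit of > 100000 nM in this assay, at which 1 of the 4 values shown sits.

Whether the bromine or the hydroxy group accounts for the steps stays open. So does what an amine or a carboxylic acid on the phenyl ring would give.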